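This account rests on a few compounds, and the source may have more. Where it says the series, first, only, none or still open, it means among the compounds named here.

Of the compounds shown here, three built on one shared core have been measured in a physicochemical assay for lipophilicity, using the shake flask method, in phosphate buffer, measured as octanol-water partition, with a stated time of 85 min, at pH 7.4; a lower number here means a more polar compound, a higher number a more lipophilic compound. Compound 1, `O=Cc1ccc(-c2cn3ccnc3c(-c3ccc4ncn(C5CCCCC5)c4c3)n2)cc1`, gives 1.5. Compound 2, `CCc1ccc(-c2cn3ccnc3c(-c3ccc4ncn(C5CCCCC5)c4c3)n2)cc1`, gives 1.66 in this assay. Compound 3, `Clc1ccc(-c2cn3ccnc3c(-c3ccc4ncn(C5CCCCC5)c4c3)n2)cc1`, gives 1.51 in this assay. Compound 3 thus stands second highest of the three numbers, with compound 1 nearest to it: a number 0.01 log units higher from compound 1 to compound 3 (within the scatter). Compound 2 is the furthest from it: a number 0.15 log units lower from compound 2 to compound 3 (within the scatter). The remaining pair, a number 0.16 log units higher from compound 1 to compound 2 (within the scatter), completes the set, and all three steps lie within the scatter.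

Compound 4, `Brc1ccc(-c2cn3ccnc3c(-c3ccc4ncn(C5CCCCC5)c4c3)n2)cc1`, has not yet been measured in this assay. The change from compound 3 is bromo in place of chloro on an aromatic carbon. Among the compounds with values here, no measured step exchanges one halogen for another, so the nearest guides are the steps that place a different group on the same aromatic carbon. Both of these, a number 0.01 log units higher from compound 1 to compound 3 (within the scatter) and a number 0.15 log units lower from compound 2 to compound 3 (within the scatter), stayed within the scatter, and the three groups tried at that carbon gave numbers barely apart. Compound 4 is therefore expected to sit close to compound 3, at most a little higher, with an expected step of a number 0.09 log units higher from compound 3 to compound 4 (within the scatter) in this assay. The estimate for compound 4 is 1.6, within a range from 1.3 to 1.9.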

Compound 4, partition coefficient: 1.73
Beside the measured number, compound 4's estimate is 0.13 log units below it; low and high end bracket the measured number.
By their numbers in this assay, from the lowest: compounds 1, 3, 2 and 4 (each within the scatter of the next).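

Within the data shown here, the first exchange of one halogen for another at this aromatic carbon, para to a large group, gives a small step in this assay (a number 0.22 log units higher from compound 3 to compound 4 (within the scatter)), so going from 4-chlorophenyl to 4-bromophenyl does not separate the two compounds in this assay. Bromo also stays close to the two non-halogen groups tried on the same carbon, both against ethyl (a number 0.07 log units higher from compound 2 to compound 4 (within the scatter)) and against formyl (a number 0.23 log units higher from compound 1 to compound 4 (within the scatter)), and that last step, the widest of all the pairs among the four compounds, still does not leave the scatter, so formyl, ethyl, chloro and bromo at this position cannot be told apart here, and no compound goes against that reading. Nothing available on these compounds speaks to why their numbers lie so close together.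

The compounds shown leave open whether an amine, a carboxylic acid or a longer chain on the same aromatic carbon would stay this close to the others. They also leave open whether fluoro or iodo would fall among these four, and whether the same closeness would hold for these groups on a different carbon of the ring.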